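Catechol and phenol diesters: removing a methoxy group

The source may hold more compounds than are shown below. What is called first, only, known or untested is meant among the compounds shown, and "the series" means these compounds.

Measured compounds:
- compound 1, `O=C(Oc1ccc(Cl)cc1OC(=O)c1ccc(O)c(O)c1)c1ccc(O)c(O)c1`: 94.4%
- compound 2, `O=C(Oc1cccc(F)c1OC(=O)c1ccc(O)c(O)c1)c1ccc(O)c(O)c1`: 88.7%
- compound 3, `COc1cccc(OC(=O)c2ccc(O)cc2)c1OC(=O)c1ccc(O)cc1`: 86.5%

All three numbers come from a functional assay on NCI-H1299 cells (Homo sapiens) for inhibition, read by scintillation counting, with a stated time of 30 min, tested at 30 uM; a higher number here means more inhibition at the concentration tested (going by the name of the read-out), a lower number less inhibition. Compound 1 gives 94.4% in this assay, compound 2 gives 88.7%, and compound 3 gives 86.5%. Compound 3 carries the smallest of the three figures, but its gap to compound 2 and its gap to compound 1 both fall within the usual scatter, so the three measured compounds cannot be told apart on these data. Within the data shown here, no pair among them differs in only one place, so no single-point step between measured compounds is available.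

The next compound, compound 4, `O=C(Oc1ccccc1OC(=O)c1ccc(O)cc1)c1ccc(O)cc1`, is obtained from compound 3 by hydrogen in place of methoxy on an aromatic carbon. Among the measured compounds shown here, nothing measured shows what this particular change does; the only guide is that every compound measured so far, with two hydroxyls or one hydroxyl on each ester, sits high in this assay.

For the measured compounds named here, with no measured step to lean on, the expectation is a step from compound 3 to compound 4 of a number 4.5 percentage points lower from compound 3 to compound 4 (within the scatter), that is, no change beyond the scatter and, if anything, a slight fall. Compound 4 is therefore estimated at 82%, with a range from 62% to 95%.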

Compound 4, a percentage reported as inhibition, at one concentration (the size of the read-out at that concentration, not a potency): 57.5%
For compound 4 the middle estimate is 24.5 percentage points above the measured one, and the stated range ends above it.
By their numbers in this assay, from the lowest: compound 4; then compounds 3, 2 and 1 (each within the scatter of the next).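

Hydrogen in place of methoxy gives a number 29 percentage points lower from compound 3 to compound 4 (beyond the scatter) in this assay and this is the first single-place step in the series, showing that a substituent on this aromatic carbon, ortho to a large group and meta to a large group, can change the read-out beyond the scatter. The earlier compounds shown here all sat high and differed from one another in more than one place, which left open whether any single position on the core of compound 3 mattered; with both hydroxylated ester groups kept unchanged, this one exchange is now enough to lower the inhibition at the concentration tested. No available data bear on the reason for this step.

Still open, from the compounds shown here alone, is whether methoxy itself is needed here, or whether an ethoxy group, a hydroxyl, a fluorine or an amine on the same aromatic carbon would hold the number as high as in compound 3. Also open, going by these compounds, is whether removing the ring substituent from the diesters with two hydroxyls on each ester, such as compound 1 and compound 2, would bring a comparable fall.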